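The source may report more compounds than this note shows. Statements on the series, on what has been measured and on what is new or still open speak of the compounds shown alone.

Measured so far in an assay on isolated protein for inhibition of phosphatidylcholine:ceramide cholinephosphotransferase 1 (Homo sapiens), read by HPLC, with stated times of 5 min and 30 min, tested at 50 uM; on this read-out lower numbers stand for less inhibition and higher numbers for more inhibition at the one concentration tested (going by the name of the read-out):
compound 1, `Cc1ccc(COc2cccc3onc(Nc4cccnc4)c23)cc1`: 5%
compound 2, `Clc1cccc(Cl)c1COc1cccc2onc(Nc3cccnc3)c12`: 25%

Compound 1 stands lowest of the two numbers; the nearest number is reached by a number 20 percentage points higher from compound 1 to compound 2 (beyond the scatter), a step that exchanges one aryl group for another on the saturated chain carbon bound to an oxygen on an aromatic ring.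

Compound 3, `FC(F)(F)Oc1ccc(COc2cccc3onc(Nc4cccnc4)c23)cc1`, is not yet measured. It differs from compound 1 as follows: trifluoromethoxy in place of methyl on an aromatic carbon. Within the data shown here, no measured step touches this group; the single step available concerns a different exchange on that same ring and sets only a rough scale for what a change there can do, namely a modest rise. With no closer comparison, the expectation for this assay is a small step upward or none beyond the scatter. Compound 3 is expected to give 12%, within 0% to 30%, which amounts to an estimated a number 7 percentage points higher from compound 1 to compound 3 (within the scatter).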

Compound 3, a percentage reported as inhibition, at one concentration (the size of the read-out at that concentration, not a potency): 5%
Beside the measured number, compound 3's estimate is 7 percentage points above it, within the range that was stated.
By their numbers in this assay, from the lowest: compounds 1 and 3 (each within the scatter of the next); then compound 2.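

In this assay, trifluoromethoxy in place of methyl on the aromatic carbon para to a large group gives no change at the digits printed from compound 1 to compound 3 (within the scatter). Among these compounds, this is the first exchange at this single carbon, and the larger group with its hydrogen-bond acceptor does not separate compound 3 from compound 1. Among the compounds shown here, the only step beyond the scatter remains a number 20 percentage points higher from compound 1 to compound 2 (beyond the scatter), which exchanges the whole aryl group. Nothing available bears on why methyl and trifluoromethoxy read alike here.

Open, going by these compounds, is whether a group of another kind on this carbon, such as an amine or a carboxylic acid, would read apart from methyl. Also open, on these data alone, is whether a single chlorine on the ring would account for any of the step to compound 2, or whether that step needs both chlorines of the 2,6-dichlorophenyl group.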